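Trifluoromethyl for tert-butyl on the aromatic carbon

The source may report more compounds than this note shows. Statements on the series, on what has been measured and on what is new or still open speak of the compounds shown alone.

Measured so far:
compound 1 `COc1ccc(C(=O)N2CCN(c3nc(N)c4cc(OC)c(OC)cc4n3)CC2)cc1OC` gives 71000 nM in a functional assay on PC-3 cells (Homo sapiens) for inhibition; a higher number here means a weaker inhibitor, a lower number a stronger inhibitor
compound 2 `COc1cc2nc(N3CCN(C(=O)c4ccc(C(C)(C)C)cc4)CC3)nc(N)c2cc1OC` gives 47000 nM in this assay

Of the compounds shown here, two have been measured, and they share one core. Compound 2 stands at 47000 nM in this assay, while compound 1 stands at 71000 nM; the step of a 1.5-fold lower number from compound 1 to compound 2 (0.18 log units; within the scatter) lies within the scatter, so the two are not told apart by the numbers. Both are weak inhibitors.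

Compound 3 `COc1cc2nc(N3CCN(C(=O)c4ccc(C(F)(F)F)cc4)CC3)nc(N)c2cc1OC` has not yet been measured. It differs from compound 2 in one place: trifluoromethyl in place of tert-butyl on an aromatic carbon.

Among the measured compounds shown here, only one measured step bears on the change, and only loosely: the step of a 1.5-fold lower number from compound 1 to compound 2 (0.18 log units; within the scatter) exchanged one group on the same aromatic carbon for another and stayed within the scatter. For the measured compounds named here, no compound with a trifluoromethyl group has been measured, so nothing in the data points in either direction. The step of a 1.1-fold higher number from compound 2 to compound 3 (0.03 log units; within the scatter) is therefore expected to be small, with no change beyond the scatter.

Compound 3 is estimated at 50000 nM, with a range from 15000 nM to 160000 nM in this assay.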

Compound 3, half-maximal inhibitory concentration: > 100000 nM
Compound 3 was reported as a limit; the forecaster's own chance of this, stated with the estimate: 20%; middle value at least 2.0-fold (0.30 log units) from the limit.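

Among the compounds shown here, at this position, on an aromatic carbon para to a large group, the exchange of tert-butyl for trifluoromethyl gives the first step in this assay that goes beyond the scatter: an at least 2.1-fold higher number from compound 2 to compound 3 (0.32 log units; beyond the scatter). So this position does respond to the group it carries, even though the two groups have the same count of heavy atoms and neither has a ring or a net charge. The exchange of 3,4-dimethoxyphenyl for 4-(trifluoromethyl)phenyl gives an at least 1.4-fold higher number from compound 1 to compound 3 (0.14 log units; that floor lies within the scatter), and with that floor inside the scatter, this step does not separate the two compounds. The value of compound 3 is a limit of the assay and not a number, so each of its steps has a floor but no known size: the limit of > 100000 nM in this assay, at which 1 of the 3 values shown sits.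

The compounds shown leave open whether any group at this position can bring the number well under that of compound 2, which gives 47000 nM; an amine, a carboxylic acid or a longer alkyl chain there would test this. They also leave open whether the tert-butyl to trifluoromethyl step would hold with another part of the shared core changed, since all three compounds differ only in this one aromatic group.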